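A side chain added to compound 2

This account rests on a few compounds, and the source may have more. Where it says the series, first, only, none or still open, it means among the compounds named here.

- compound 1 `CN1CCN(CCCn2nc(C3=C(c4cn(C)c5ccccc45)C(=O)NC3=O)c3cccnc32)CC1`: > 100000 nM, a limit
- compound 2 `Cn1cc(C2=C(c3n[nH]c4ncccc34)C(=O)NC2=O)c2ccccc21`: 62000 nM

Among the compounds with values here, in a functional assay on KB cells (Homo sapiens) for antiproliferative activity, read by MTT assay, with a stated time of 48 h (on this read-out higher numbers stand for weaker inhibition and lower numbers for stronger inhibition), compound 2 gives 62000 nM, the only number obtained so far. Compound 1 gives > 100000 nM, which is a limit of the assay and not a number.

The next compound, compound 3 `Cn1cc(C2=C(c3nn(CCCN4CCCCC4)c4ncccc34)C(=O)NC2=O)c2ccccc21`, is still unmeasured. It differs from compound 2 as follows: 3-(piperidin-1-yl)propyl in place of hydrogen on an aromatic nitrogen. In words, 3-(piperidin-1-yl)propyl stands in place of hydrogen on an aromatic nitrogen.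

Within the data shown here, one measured step bears on this change. It removes 3-(4-methylpiperazin-1-yl)propyl from an aromatic nitrogen, and it amounts to an at least 1.6-fold lower number from compound 1 to compound 2 (0.20 log units; that floor lies within the scatter). That step fixes no firm size, so no change beyond the scatter is expected in this assay.

The estimated step is a 1.1-fold lower number from compound 2 to compound 3 (0.05 log units; within the scatter). For compound 3 the expected value is 55000 nM. The expected range runs from 15000 nM to 150000 nM.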

Compound 3, half-maximal inhibitory concentration: 98000 nM
Estimate against measurement, compound 3: 1.8-fold (0.25 log units) below; measured number inside the range.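

In this assay, putting 3-(piperidin-1-yl)propyl on the aromatic nitrogen gives a 1.6-fold higher number from compound 2 to compound 3 (0.20 log units; within the scatter) and so gives this position its first step with a number at both ends, a step that stays inside the scatter. Exchanging the chain's end group reads as an at least 1.0-fold lower number from compound 1 to compound 3 (0.00 log units; that floor lies within the scatter) and fixes no size for piperidin-1-yl against 4-methylpiperazin-1-yl. Compound 1 gives > 100000 nM which is a limit of the assay and not a number, so this exchange can be read no further than that limit: the limit of > 100000 nM in this assay, at which 1 of the 3 values shown sits.

On these data alone, it remains open whether a small methyl group, a shorter chain or a chain ending in morpholine on this nitrogen would move the number beyond the scatter from that of compound 2. As far as these compounds go, whether any group here gives stronger inhibition also stays open.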